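Ethoxycarbonyl in place of methyl on the core of compound 1

The source may report more compounds than this note shows. Statements on the series, on what has been measured and on what is new or still open speak of the compounds shown alone.

Two analogues of the shared core carry numbers in a functional assay on the whole organism with Rattus norvegicus as the target, read by paw edema, with a stated time of 3 h, at a dose of 100 mg/kg by the oral route; a lower number here means less inhibition, a higher number more inhibition at the dose given (going by the name of the read-out). Compound 1 `Cc1ccc(-c2nc3ccccc3[nH]2)nc1` gives 19%, the lowest of the two numbers. For the measured compounds named here, compound 2 `Cc1cccc(-c2nc3ccccc3[nH]2)n1` gives 44% in this assay, a number beyond the scatter above that of compound 1; no single-change step between these two is drawn, so only what the two values show is stated. Compound 3 `CCOC(=O)c1ccc(-c2nc3ccccc3[nH]2)nc1` is not yet measured in this assay. It differs from compound 1 in one place: ethoxycarbonyl in place of methyl on an aromatic carbon. The change sits on an aromatic carbon of a six-membered aromatic ring with 1 nitrogen, two atoms from the ring nitrogen, para to a group of 9 heavy atoms. Going by the values given here, no measured step of this kind exists, so a small step is expected in this assay, in either direction or none beyond the scatter. The step expected from compound 1 to compound 3 is a number 9 percentage points higher from compound 1 to compound 3 (within the scatter). Compound 3 is estimated at 28%, in a range from 8% to 50%.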

Compound 3, a percentage reported as inhibition, in the whole organism at one dose (the size of the read-out at that dose, not a potency): -16%
The estimate for compound 3 lay 44 percentage points above the measured number; the whole stated range lies above it.
By their numbers in this assay, from the lowest: compound 3; then compound 1; then compound 2.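

This position on the core of compound 1 is not indifferent to the group it carries: in this assay, ethoxycarbonyl in place of methyl on this aromatic carbon gives a number 35 percentage points lower from compound 1 to compound 3 (beyond the scatter). Compound 3 gives -16%, a negative number, so the modest inhibition of the methyl compound does not carry over to the ethoxycarbonyl compound at the dose given. No measurement shown here accounts for this step.

The compounds shown do not tell whether the drop follows the ester itself or simply a larger group on this carbon; a carboxylic acid, an amide or a longer alkyl chain at the same place would separate these readings. On these data alone, whether ethoxycarbonyl would have a similar effect in place of the methyl of compound 2 also remains open.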